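Working notes: compound 2 to compound 4

The source may hold more compounds than are shown below. What is called first, only, known or untested is meant among the compounds shown, and "the series" means these compounds.

Measured in a functional assay on HCT-116 cells (Homo sapiens) for antiproliferative activity, read by MTT assay, with a stated time of 72 h; a higher number here means a weaker inhibitor, a lower number a stronger inhibitor:
- compound 1 `O=C(CCc1cccc2c1B(O)OC2)NCc1ccccc1`: > 100000 nM (a limit, not a number)
- compound 2 `O=C(CCc1cccc2c1B(O)OC2)Nc1cccc(Br)c1`: 1400 nM
- compound 3 `Cc1ccc(NC(=O)CCc2cccc3c2B(O)OC3)cc1Br`: 1200 nM

Compound 2 stands level with compound 3 among the two numerical values: a 1.2-fold lower number from compound 2 to compound 3 (0.07 log units; within the scatter). Compound 4 `O=C(CCc1cccc2c1B(O)OC2)Nc1cccc(-c2ccc(Cl)cc2)c1` carries 4-chlorophenyl in place of bromo on an aromatic carbon. For the measured compounds named here, no measured step changes this group. The large step of an at least 71-fold lower number from compound 1 to compound 2 (1.85 log units; beyond the scatter) concerns the group on the amide-type nitrogen, and the methyl step, within the scatter, is far smaller in size than the new group. A modest shift to a lower number is therefore expected, with a wide margin. The expected step is a 1.6-fold lower number from compound 2 to compound 4 (0.19 log units; within the scatter). Compound 4 is estimated at 900 nM, with an expected range of 200 nM to 4000 nM.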

Compound 4, half-maximal inhibitory concentration: 380 nM
Compound 4: the middle estimate sits 2.4-fold (0.37 log units) above what was measured; low and high end bracket the measured number.
By their numbers in this assay, from the lowest: compound 4; then compounds 3 and 2 (each within the scatter of the next). At a limit, above all of these: compound 1.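

In this assay, the step of a 3.7-fold lower number from compound 2 to compound 4 (0.57 log units; beyond the scatter) is the first change shown at this position. The aromatic carbon that held bromo also tolerates 4-chlorophenyl, a group of 7 heavy atoms with a further aromatic ring, and the number falls rather than rises. Nothing measured here accounts for this step. As far as these compounds go, how a plain phenyl, an amine or a carboxylic acid at this carbon would compare remains open. So does whether the chlorine or the added ring carries the step.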